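This account rests on a few compounds, and the source may have more. Where it says the series, first, only, none or still open, it means among the compounds named here.

Measured compounds:
compound 1 `Cc1cc2cc(NCc3cc(C(=O)NO)ccc3Cl)ccc2n(C)c1=O`, 3190 nM
compound 2 `Cc1cc2cc(NC(=O)c3cc(C(=O)NO)ccc3Cl)ccc2n(C)c1=O`, 113 nM

In an assay on isolated protein for inhibition of histone deacetylase 8 (Homo sapiens), read by fluorescence, with a stated time of 90 min (a higher number here means a weaker inhibitor, a lower number a stronger inhibitor), compound 1 gives 3190 nM, the higher of the two numbers measured. Compound 2 gives 113 nM in this assay, a lower number by a margin beyond the scatter, so compound 1 is the weaker inhibitor of the pair.

Compound 3 `COc1ccc(C(=O)NO)cc1CNc1ccc2c(c1)cc(C)c(=O)n2C` is not yet measured. It differs from compound 1 in one place: methoxy in place of chloro on an aromatic carbon. Going by the values given here, no measured pair shows this change, so the step is open; the writer expects at most a small change from compound 1 to compound 3, not clearly beyond the scatter, as the estimated step of a 1.3-fold higher number from compound 1 to compound 3 (0.10 log units; within the scatter) says. Compound 3 is therefore expected to give about 4000 nM, within a range from 1500 nM to 12000 nM.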

Compound 3, half-maximal inhibitory concentration: 555 nM
Estimate against measurement, compound 3: 7.2-fold (0.86 log units) above; the measured number lies below the stated range.
By their numbers in this assay, from the lowest: compound 2; then compound 3; then compound 1.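

In this assay the change from chloro to methoxy, para to the hydroxycarbamoyl group, brings a 5.7-fold lower number from compound 1 to compound 3 (0.76 log units; beyond the scatter) and so lies beyond the scatter. Compound 1 and compound 2 both carry chloro here, so only now does this aromatic carbon prove able to shift the number. Nothing available explains the step. As far as these compounds go, whether an amine, a hydroxy group or a plain hydrogen at this place would lower the number as well stays open. So does whether methoxy would do the same on compound 2.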